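Swapping trifluoromethyl for trifluoromethoxy on a shared core

This account rests on a few compounds, and the source may have more. Where it says the series, first, only, none or still open, it means among the compounds named here.

Measured compounds:
compound 1 `Oc1cccc(-c2cc(-c3cccc(C(F)(F)F)c3)cc(-c3cccc(O)c3)n2)c1`: 13600 nM
compound 2 `Oc1ccc(-c2cc(-c3cccc(C(F)(F)F)c3)cc(-c3cccc(O)c3)n2)cc1`: 9540 nM

Going by the values given here, in a functional assay on HCT-15 cells (Homo sapiens) for inhibition (on this read-out higher numbers stand for weaker inhibition and lower numbers for stronger inhibition), compound 1 gives 13600 nM, the higher of the two numbers measured so far. Compound 2 gives 9540 nM, and the step of a 1.4-fold lower number from compound 1 to compound 2 (0.15 log units; within the scatter) shows that exchanging one hydroxyphenyl group for another leaves the read-out essentially unchanged. Compound 3 `Oc1cccc(-c2cc(-c3cccc(OC(F)(F)F)c3)cc(-c3cccc(O)c3)n2)c1` differs from compound 1 in a different part of the molecule: trifluoromethoxy in place of trifluoromethyl on an aromatic carbon. Among the compounds with values here, no measured step touches the trifluoromethyl group, so the only measured step, which concerns the hydroxyphenyl group, does not bear on this change. Without guidance from the data, the expectation is a step within the scatter, a 1.1-fold lower number from compound 1 to compound 3 (0.05 log units; within the scatter), with the direction uncertain. Compound 3 is therefore estimated at 12000 nM, with a range from 5000 nM to 30000 nM.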

Compound 3, half-maximal inhibitory concentration: > 50000 nM
Compound 3: no number, only a limit; the forecaster's own chance of this, stated with the estimate: 10%; at least 4.1-fold (0.61 log units) between middle value and limit.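

Trifluoromethoxy in place of trifluoromethyl, on an aromatic carbon meta to a large group, gives an at least 3.6-fold higher number from compound 1 to compound 3 (0.56 log units; beyond the scatter) in this assay. The step rests on a limit of the assay for compound 3, not on a number: the limit of > 50000 nM in this assay, at which 1 of the 3 values shown sits. The one earlier step, on the hydroxyphenyl group, stayed within the scatter, so this is the first change among these compounds to move the read-out beyond it, showing that this position does not accept every similar group alike.

A single pair cannot tell which feature of the trifluoromethoxy group matters. On these data alone, whether a methoxy group, a chlorine atom or a plain hydrogen here would behave like trifluoromethyl or like trifluoromethoxy stays open, as does whether the same exchange would act alike on the core of compound 2.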